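The compounds below may be only part of what the source reports. "The series", "measured", "known", "first", "only" and "open" are said of these compounds alone.

In a functional assay on HEL cells (Homo sapiens) (a higher number here means that more compound is tolerated, a lower number that less compound is tolerated), compound 1 `COC(=O)CNC1=CS(=O)(=O)O[C@@]12[C@@H](CO[Si](C)(C)C(C)(C)C)O[C@@H](n1cc(C)c(=O)n(C)c1=O)[C@@H]2O[Si](C)(C)C(C)(C)C` gives 160000 nM. Compound 2 `COC(=O)C(=O)CNC1=CS(=O)(=O)O[C@@]12[C@@H](CO[Si](C)(C)C(C)(C)C)O[C@@H](n1cc(C)c(=O)n(C)c1=O)[C@@H]2O[Si](C)(C)C(C)(C)C` gives > 200000 nM, which is a limit of the assay and not a number. It therefore stands at the limit of > 200000 nM in this assay, at which 1 of the 2 values shown sits. Among the compounds with values here, the only measured step that bears on what follows is an at least 1.2-fold higher number from compound 1 to compound 2 (0.09 log units; that floor lies within the scatter), so the data show no clear change so far.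

Compound 3 `Cc1cn([C@@H]2O[C@H](CO[Si](C)(C)C(C)(C)C)[C@@]3(OS(=O)(=O)C=C3NCCC(=O)O)[C@H]2O[Si](C)(C)C(C)(C)C)c(=O)n(C)c1=O` differs from compound 2 as follows: carboxymethyl in place of (methoxycarbonyl)carbonyl on a saturated chain carbon bound to an amine nitrogen. In words, carboxymethyl stands in place of (methoxycarbonyl)carbonyl on a saturated chain carbon bound to an amine nitrogen. Within the data shown here, since the one earlier step, an at least 1.2-fold higher number from compound 1 to compound 2 (0.09 log units; that floor lies within the scatter), shows nothing beyond the scatter, no step beyond the scatter is expected in this assay, in either direction. This expectation rests on very little evidence. The estimated step is an at least 1.1-fold lower number from compound 2 to compound 3 (0.07 log units; that floor lies within the scatter). For compound 3 the expected value is 170000 nM, within an estimated range of 80000 nM to 300000 nM.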

Compound 3, half-maximal cytotoxic concentration: 34000 nM
Compound 3: middle estimate off by 5.0-fold (0.70 log units), on the high side; the measured number lies below the stated range.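

Within the data shown here, this position is the first to show a change beyond the scatter in this assay, and the change is toward less compound being tolerated. Carboxymethyl in place of methoxycarbonyl gives a 4.7-fold lower number from compound 1 to compound 3 (0.67 log units; beyond the scatter), and carboxymethyl in place of (methoxycarbonyl)carbonyl gives an at least 5.8-fold lower number from compound 2 to compound 3 (0.76 log units; beyond the scatter). The second step is only a floor because compound 2 sits at a limit of the assay: the limit of > 200000 nM in this assay, at which 1 of the 3 values shown sits.

Each step swaps the whole group, so the compounds shown do not separate the effect of the free carboxyl end from that of the chain carrying it. As far as these compounds go, whether 2-(methoxycarbonyl)ethyl, an amide or an amine on this saturated chain carbon bound to an amine nitrogen would give a number like that of compound 3 stays open.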